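Dropping the chloro from a potent sulfonamide

The source may hold more compounds than are shown below. What is called first, only, known or untested is meant among the compounds shown, and "the series" means these compounds.

Measured compounds:
compound 1 `O=C(NCc1ccc(CNS(=O)(=O)c2ccc([N+](=O)[O-])cc2)cc1)c1ccc(CNc2ncccn2)cc1`: 1000 nM
compound 2 `O=C(NCc1ccc(CNS(=O)(=O)c2cccc(Cl)c2)cc1)c1ccc(CNc2ncccn2)cc1`: 1 nM

For the measured compounds named here, in an assay on MDA-MB-231 cells for binding affinity to C-X-C chemokine receptor type 4 (Homo sapiens), read by microscopy, with stated times of 10 min and 30 min (a higher number here means that more compound is needed for the effect, a lower number that less compound is needed), compound 2 gives 1 nM, the lowest of the two numbers known; its nearest neighbour, compound 1, gives 1000 nM. Going by the values given here, the one measured step, a 1000-fold lower number from compound 1 to compound 2 (3.00 log units; beyond the scatter), is large and runs beyond the scatter, but it exchanges the whole aryl group on the sulfonyl sulfur, 3-chlorophenyl in place of 4-nitrophenyl, and so says little about the chloro on its own.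

Compound 3 `O=C(NCc1ccc(CNS(=O)(=O)c2ccccc2)cc1)c1ccc(CNc2ncccn2)cc1` keeps the core of compound 2 and differs only in this: hydrogen in place of chloro on an aromatic carbon. Among the compounds with values here, no measured step isolates the chloro, so the direction rests on the pattern that compound 1, the only other point, sits far higher. On that thin basis compound 3 is expected to give a somewhat higher number than compound 2, an estimated step of a 10-fold higher number from compound 2 to compound 3 (1.00 log units; beyond the scatter). The estimate for compound 3 is 10 nM, with a range from 1.5 nM to 100 nM.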

Compound 3, effective concentration (reported as EC, without a stated level of effect): 1 nM
Compound 3: middle estimate off by 10-fold (1.00 log units), on the high side; the measured number lies below the stated range.
By their numbers in this assay, from the lowest: compounds 2 and 3 (each within the scatter of the next); then compound 1.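

In this assay, hydrogen in place of chloro gives no change at the digits printed from compound 2 to compound 3 (within the scatter), so the chloro on this aromatic carbon is not needed to hold the low number, and 3-chlorophenyl and phenyl on the sulfonyl sulfur cannot be told apart here. Hydrogen in place of nitro gives a 1000-fold lower number from compound 1 to compound 3 (3.00 log units; beyond the scatter), a single-place step that ties the large gap to the nitro of compound 1, which the earlier exchange of whole aryl groups could not do. Nothing available explains why one substituent leaves the number unmoved while the other goes with so large a gap.

From the compounds shown here alone, whether an amine or a carboxylic acid on this aromatic carbon would group with compound 2 and compound 3 or with compound 1 remains open. Also open, going by these compounds, is whether a nitro on the aromatic carbon that carries the chloro in compound 2 would match compound 1, which would separate the group from its place on the ring.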